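The compounds below may be only part of what the source reports. "The series", "measured", "known", "first", "only" and "open" are said of these compounds alone.

Working notes on the series.

Compound 1, `CN(c1cccc2c1CN(c1nc(Nc3ccc(C(F)(F)F)cc3)ncc1C(F)(F)F)C2)S(C)(=O)=O`, is the reference point. In a functional assay on U-87MG ATCC cells for antiproliferative activity against U-87 MG (Homo sapiens), read by spectrophotometry, with a stated time of 2 days (a higher number here means a weaker inhibitor of growth, a lower number a stronger inhibitor of growth), compound 1 gives > 30000 nM, which is a limit of the assay and not a number, so compound 1 stands at the top of the measured values only as a limit (the limit of > 30000 nM in this assay, at which 2 of the 3 values shown sit).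

Two measured neighbours share the core. Compound 2, `CN(c1cccc2c1CN(c1nc(Nc3cc(Cl)cc(C(F)(F)F)c3)ncc1C(F)(F)F)C2)S(C)(=O)=O`, gives 5500 nM in this assay, and the step of an at least 5.4-fold lower number from compound 1 to compound 2 (0.73 log units; beyond the scatter). Compound 3, `Cc1ccc(Nc2ncc(C(F)(F)F)c(N3Cc4cccc(N(C)S(C)(=O)=O)c4C3)n2)cc1C`, returns > 30000 nM in this assay, which is again a limit. The step that the two limits leave unreadable from compound 1 to compound 3, while the step of an at least 5.4-fold higher number from compound 2 to compound 3 (0.73 log units; beyond the scatter).

Compound 4, `Cc1cc(F)ccc1Nc1ncc(C(F)(F)F)c(N2Cc3cccc(N(C)S(C)(=O)=O)c3C2)n1`, is not yet measured. The change (4-fluoro-2-methylphenyl in place of 4-(trifluoromethyl)phenyl on a nitrogen on an aromatic ring). The steps from compound 1 to compound 2 and to compound 3 bear on it: only the 3-chloro-5-(trifluoromethyl)phenyl gave a readable improvement, and the 3,4-dimethylphenyl stayed at the limit. A methyl and a single fluorine resemble compound 3 more than compound 2, so for compound 4 no step beyond the scatter is expected, a number no higher from compound 1 to compound 4 (the limit leaves the size open), and the value is most likely to come back as a limit. The estimate for compound 4 in this assay is 30000 nM, with a range from 8000 nM to 100000 nM.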

Compound 4, concentration for 50% growth inhibition: > 30000 nM
Compound 4 ended at the assay's limit; the forecaster's own chance of this, stated with the estimate: 65%; the middle value lies on the limit itself.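

In this assay compound 4 gives > 30000 nM, which is a limit of the assay and not a number. Among the compounds shown here, the one readable step is an at least 5.4-fold higher number from compound 2 to compound 4 (0.73 log units; beyond the scatter); the steps to compound 4 from compound 1 and from compound 3 cannot be read. With 4-fluoro-2-methylphenyl on this nitrogen, a second replacement for 4-(trifluoromethyl)phenyl fails to give a readable value, and 3-chloro-5-(trifluoromethyl)phenyl remains the only one of the four groups shown to do so: the limit of > 30000 nM in this assay, at which 3 of the 4 values shown sit.

The compounds shown leave open whether the chlorine, the trifluoromethyl or the two together account for the readable value of compound 2. On these data alone, what a 3,5-dichlorophenyl, or a phenyl carrying an amine or a carboxylic acid, would give on this nitrogen also stays open.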